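A few compounds are considered here, and "the series" means these few. Any claim that something is new, unique, unknown or untested is made for them only; others in the source may bear on it.

Compounds measured so far in an ADME assay on U2OS cells (Homo sapiens) for cytotoxicity; a lower number here means that less compound is tolerated, a higher number that more compound is tolerated:

Compound 1 `CC(C)(O)c1cc2c(-c3ccccc3CO)nccc2[nH]1`: "not determined" (no result reported)
Compound 2 `CC(C)(O)c1cc2c(-c3ccsc3)nccc2[nH]1`: 199000 nM
Compound 3 `CC(=O)c1ccc(-c2nccc3[nH]c(C(C)(C)O)cc23)cc1`: "not determined" (no result reported)

Compound 3 has no single number to stand on, since its entry reads "not determined" (no result reported). Compound 1 is in the same position, with "not determined" (no result reported). Within the data shown here, that leaves compound 2 as the only compound with a measured value, at 199000 nM.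

The next compound to be tested is compound 4 `CC(C)(O)c1cc2c(-c3ccccc3)nccc2[nH]1`. The structural change is hydrogen in place of acetyl on an aromatic carbon, para to a large group.

Among the measured compounds shown here, no measured step between two related compounds exists, and without a number for compound 3, the size of this change in this assay cannot be read from the data. The working expectation is therefore no step beyond the scatter, in either direction, with compound 2 at 199000 nM as the only anchor.

For compound 4, the half-maximal cytotoxic concentration is expected to be about 150000 nM, within an estimated range of 50000 nM to 400000 nM.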

Compound 4, half-maximal cytotoxic concentration: 22200 nM
Compound 4: the middle estimate sits 6.8-fold (0.83 log units) above what was measured; measured number outside the range, below it.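

In this assay the group on this aromatic carbon of the shared core turns out to matter: phenyl in place of thiophen-3-yl gives a 9.0-fold lower number from compound 2 to compound 4 (0.95 log units; beyond the scatter) and this lies beyond the scatter. Less of compound 4 is therefore tolerated, which shows that exchanging one aromatic ring for another at this place is enough to move the read-out, although this rests on a single pair of compounds. Nothing available here accounts for the size or direction of this step.

On these data alone, the step from compound 3 to compound 4 cannot be read, as compound 3 has no number, so the effect of acetyl on the phenyl ring stays unknown. Also open, as far as these compounds go, is how an amine or a carboxylic acid in that same place on the phenyl ring would compare with the hydrogen of compound 4.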